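The source may hold more compounds than are shown below. What is called first, only, known or untested is meant among the compounds shown, and "the series" means these compounds.

For the measured compounds named here, compound 3 `CCCCCCCCc1ccc(OCC(=O)Cn2nnnc2SC)cc1` gives 22 nM in an assay on microsomes from brain for inhibition of Fatty-acid amide hydrolase 1 (Rattus norvegicus), read by fluorescence and HPLC, with a stated time of 60 min (a lower number here means a stronger inhibitor, a higher number a weaker inhibitor), the lowest of the three numbers measured so far, though its neighbours sit within the scatter: compound 1 `CCCCCCCCc1ccc(OCC(=O)Cn2nnc(C)n2)cc1` gives 27 nM and compound 2 `CCCCCCCCc1ccc(OCC(=O)Cn2nnc(SC)n2)cc1` gives 31 nM. Compound 4 `CCCCCCCCc1ccc(OCC(=O)Cn2nnnc2Cc2ccccc2)cc1` differs from compound 3 by benzyl in place of methylsulfanyl on an aromatic carbon. Going by the values given here, the one measured step that touches the substituent at that aromatic carbon, a 1.1-fold higher number from compound 1 to compound 2 (0.06 log units; within the scatter), lay within the scatter, as did the ring-attachment steps a 1.2-fold lower number from compound 1 to compound 3 (0.09 log units; within the scatter) and a 1.4-fold lower number from compound 2 to compound 3 (0.15 log units; within the scatter). Among the compounds with values here, no measured step tells how a benzyl group fares there, so only a small step is expected for compound 4, in no firm direction. Compound 4 is therefore estimated at 20 nM, with a range from 7 nM to 60 nM, a step of a 1.1-fold lower number from compound 3 to compound 4 (0.04 log units; within the scatter).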

Compound 4, half-maximal inhibitory concentration: 320 nM
Compound 4: the middle estimate sits 16-fold (1.20 log units) below what was measured, and the stated range ends below it.
By their numbers in this assay, from the lowest: compounds 3, 1 and 2 (each within the scatter of the next); then compound 4.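

At this aromatic carbon, between two ring nitrogen atoms, the substituent does matter in this assay: benzyl in place of methylsulfanyl gives a 15-fold higher number from compound 3 to compound 4 (1.16 log units; beyond the scatter), whereas every earlier step stayed within the scatter. For the compounds shown here, the data show only that this larger group, with its six-membered aromatic ring, is poorly tolerated here, and nothing given explains the change. The compounds shown do not tell how a phenyl group, an ethyl group or an amine would fare at this carbon. From the compounds shown here alone, whether benzyl has the same effect on the 2H-tetrazol-2-yl attachment of compound 1 also stays open.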